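This account rests on a few compounds, and the source may have more. Where it says the series, first, only, none or still open, it means among the compounds named here.

Compound 1 `O=C(NO)c1ccc(CN(Cc2ccc(F)cc2)S(=O)(=O)c2c(F)c(F)c(F)c(F)c2F)cc1` is the weaker of the two compounds that give a number in an assay on isolated protein for inhibition of histone deacetylase 11 (Homo sapiens), read by mobility shift assay (a higher number here means a weaker inhibitor, a lower number a stronger inhibitor), where compound 1 gives 787 nM. Compound 3 `Cc1ccc(CN(Cc2ccc(C(=O)NO)cc2)S(=O)(=O)c2c(F)c(F)c(F)c(F)c2F)cc1` gives 73 nM in this assay, and the step of an 11-fold lower number from compound 1 to compound 3 (1.03 log units; beyond the scatter) is large. Compound 2 `O=C(NO)c1ccc(CN(Cc2ccc(C(F)(F)F)cc2)S(=O)(=O)c2c(F)c(F)c(F)c(F)c2F)cc1` gives only a limit of this assay, > 1000 nM; one of the three values shown sits at the limit (the limit of > 1000 nM in this assay, at which 1 of the 3 values shown sits). The step of an at least 1.2-fold higher number from compound 1 to compound 2 (0.10 log units; that floor lies within the scatter) therefore has only a floor.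

Compound 4 `O=C(NO)c1ccc(CN(Cc2ccc(F)cc2)S(=O)(=O)c2cc(F)c(F)c(F)c2F)cc1` differs from compound 1 by hydrogen in place of fluoro on an aromatic carbon. Within the data shown here, both measured steps alter a different part of the molecule, the group on the other aromatic ring, so neither bears directly on the change from compound 1 to compound 4; the data give no step at the 2,3,4,5,6-pentafluorophenyl ring. With nothing shown to speak for a shift, the expected step is a 1.0-fold higher number from compound 1 to compound 4 (0.01 log units; within the scatter), within the scatter. Compound 4 is estimated to give 800 nM in this assay, expected between 300 nM and 2500 nM.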

Compound 4, half-maximal inhibitory concentration: > 1000 nM
Compound 4 ended at the assay's limit; the forecaster's own chance of this, stated with the estimate: 30%; at least 1.2-fold (0.09 log units) between middle value and limit.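

This is the first change shown on the 2,3,4,5,6-pentafluorophenyl ring, and in this assay compound 4 gives > 1000 nM, which is a limit of the assay. The step is an at least 1.2-fold higher number from compound 1 to compound 4 (0.10 log units; that floor lies within the scatter), so replacing this fluoro group with hydrogen, ortho to a large group, shows no gain in inhibition, but the result cannot say whether the loss of this fluoro group weakens inhibition at all. The top of the measurable range now holds both compound 2 and compound 4: the limit of > 1000 nM in this assay, at which 2 of the 4 values shown sit.

As far as these compounds go, how far compound 4 lies past the limit remains open, and so does whether the methyl group of compound 3 would bring a similar step on the 2,3,4,5-tetrafluorophenyl ring. From the compounds shown here alone, it is also open what a chloro group, a methoxy group or an amine would do at this place.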